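A few compounds are considered here, and "the series" means these few. Any claim that something is new, unique, unknown or untested is made for them only; others in the source may bear on it.

Compound 1 `COc1cc(-n2ncnc2-c2ccc(OC(C)C)cc2)cc(OC)c1OC` is the one of the three measured compounds that returns a number in a functional assay on Jurkat cells (Homo sapiens) for antiproliferative activity, read by MTT assay, with a stated time of 72 h (a lower number here means a stronger inhibitor, a higher number a weaker inhibitor), where compound 1 gives 650 nM. Compound 2 `COc1ccccc1-c1ncnn1-c1cc(OC)c(OC)c(OC)c1` reaches the limit of the assay, > 10000 nM. Compound 3 `COc1cc(-c2ncnn2-c2cccc(N)c2)cc(OC)c1OC` likewise stops at the limit, > 10000 nM. So compound 3 stands at the limit of > 10000 nM in this assay, at which 2 of the 3 values shown sit, with no number of its own. Compound 4 `COc1cc(-c2ncnn2-c2ccc(Cl)c(Cl)c2)cc(OC)c1OC` has yet to be tested. The change is 3,4-dichlorophenyl in place of 3-aminophenyl on an aromatic nitrogen. With compound 3 at a limit rather than a value, the step can only be judged against that limit, and the expected step of a number no higher from compound 3 to compound 4 (the limit leaves the size open) is small, with compound 4 likely to stay near or past the limit. Compound 4 is expected to show about 10000 nM, in a range from 2000 nM to 50000 nM.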

Compound 4, half-maximal inhibitory concentration: > 10000 nM
Compound 4 gave a limit, no number; the forecaster's own chance of this, stated with the estimate: 65%; the middle value sits exactly at the limit.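

Compound 3 and compound 4 both stop at a limit in this assay, so no step between them can be read: the limit of > 10000 nM in this assay, at which 3 of the 4 values shown sit.

On these data alone, whether 3,4-dichlorophenyl in place of 3-aminophenyl changes activity at all stays open.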